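The compounds below may be only part of what the source reports. "The series", "measured", "known", "first", "only" and "open" are said of these compounds alone.

Of the compounds shown here, three have been tested in a toxicity assay on THP-1 cells (Homo sapiens) for inhibition; on this read-out lower numbers stand for higher toxicity in this test and higher numbers for lower toxicity in this test. Compound 1 `COc1ccc(-c2ccc(NC(=O)c3ccc(F)cc3)nc2)cc1` gives > 100000 nM, which is a limit of this assay rather than a number. Compound 2 `COc1ccc(-c2cnc(NC(=O)c3cccc(O)c3)n2C)cc1` gives > 100000 nM, again a limit of this assay and not a number. Compound 3 `O=C(Nc1ncc(-c2ccccc2)o1)c1ccc(F)cc1` gives a measured value of 17000 nM. On the numbers shown, compound 2 stands at the upper end, at the limit where two of the three results sit (the limit of > 100000 nM in this assay, at which 2 of the 3 values shown sit), so its value is known only as a bound.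

Compound 4 `COc1ccc(-c2cnc(NC(=O)c3ccncc3)n2C)cc1` is the next compound, not yet measured in this assay. Compared with compound 2 the change is pyridin-4-yl in place of 3-hydroxyphenyl on a carbonyl carbon: a pyridin-4-yl in place of a 3-hydroxyphenyl on the carbonyl carbon.

Among the compounds with values here, no measured pair differs in one place, so there is no measured step to lean on. Compound 1 and compound 2 both reach the limit while compound 3 does not, and the structural change here is small. The expected step of a number no higher from compound 2 to compound 4 (the limit leaves the size open) is therefore none beyond the scatter. Compound 4 is expected to give about 100000 nM in this assay, with a range from 30000 nM to 300000 nM, and quite possibly only a limit again.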

Compound 4, half-maximal cytotoxic concentration: > 100000 nM
Compound 4 gave a limit, no number; the forecaster's own chance of this, stated with the estimate: 60%; the middle value lies on the limit itself.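

Within the data shown here, compound 2 and compound 4 each give only a limit of this assay, not a number, so no step between them can be read: the limit of > 100000 nM in this assay, at which 3 of the 4 values shown sit.

Going by these compounds, whether pyridin-4-yl in place of 3-hydroxyphenyl on the carbonyl carbon changes the result at all stays open.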